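A Pyrazole Replaces the Pyridine on the Sulfonamide Nitrogen

A few compounds are considered here, and "the series" means these few. Any claim that something is new, unique, unknown or untested is made for them only; others in the source may bear on it.

Compound 1 `Cc1ccc(S(=O)(=O)N(CC(=O)NCc2ccc(Cl)cc2)c2ncccc2C)cc1` is measured in an assay on CHO cells for displacement of a labelled ligand from prostaglandin E2 receptor EP1 subtype (Homo sapiens) (a higher number here means a weaker inhibitor, a lower number a stronger inhibitor), at 794 nM. Compound 2 `Cc1ccc(S(=O)(=O)N(CC(=O)NCc2ccc(Cl)cc2)c2ccc(C)cn2)cc1` is recorded in this assay only as < 1000 nM, which is a limit of the assay rather than a number. Because of that (the limit of < 1000 nM in this assay, at which 1 of the 2 values shown sits), the step that the limit leaves unreadable from compound 1 to compound 2 cannot be sized, so where compound 2 stands is known only as a range, not as a point. Compound 3 `Cc1ccc(S(=O)(=O)N(CC(=O)NCc2ccc(Cl)cc2)c2ccnn2C)cc1` has not yet been measured. It differs from compound 2 in one place: 1-methyl-1H-pyrazol-5-yl in place of 5-methylpyridin-2-yl on a sulfonamide nitrogen. Among the compounds with values here, the only measured step that bears on an exchange at the sulfonamide nitrogen is the one from compound 1 to compound 2, and it is unreadable, so no direction can be drawn from it for this assay. The estimate for compound 3 is therefore 800 nM, with a range from 150 nM to 4000 nM. That estimate corresponds to an expected step that the limit leaves unreadable from compound 2 to compound 3.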

Compound 3, inhibition constant: 398 nM
Beside the measured number, compound 3's estimate is 2.0-fold (0.30 log units) above it; the range from low to high includes it.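

In this assay, within the data shown here, 1-methyl-1H-pyrazol-5-yl in place of 3-methylpyridin-2-yl on the sulfonamide nitrogen gives the first step at this position that can be read: a 2.0-fold lower number from compound 1 to compound 3 (0.30 log units; within the scatter). A five-membered aromatic ring with 2 hetero atoms can therefore stand on this nitrogen where a six-membered aromatic ring with 1 hetero atom stood, with no difference that can be told from scatter between these two compounds. Compound 2 is recorded only as a limit, and the steps that touch it cannot be read because of that: the limit of < 1000 nM in this assay, at which 1 of the 3 values shown sits.

The compounds shown leave open where compound 2 truly stands relative to the other two. They also leave open whether a plain phenyl ring or a saturated ring such as piperidine on this nitrogen would give a step beyond the scatter.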